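Swapping the Aryl Group on a Shared Core

The source may report more compounds than this note shows. Statements on the series, on what has been measured and on what is new or still open speak of the compounds shown alone.

Two compounds share one core and differ only in the aromatic ring attached to a double-bonded chain carbon. Compound 1 `C=CCn1c(=O)/c(=C\c2cccc(Br)c2)[nH]c(=O)/c1=C\c1ccccc1OC` carries a 3-bromophenyl there; in a functional assay on HL-60 cells (Homo sapiens) for cytotoxicity, read by CCK-8 assay, with a stated time of 72 h (on this read-out higher numbers stand for weaker inhibition and lower numbers for stronger inhibition), compound 1 gives 5200 nM. Compound 2 `C=CCn1c(=O)/c(=C\c2ccccc2C(F)(F)F)[nH]c(=O)/c1=C\c1ccccc1OC` carries a 2-(trifluoromethyl)phenyl instead, and in this assay compound 2 gives 4600 nM. The step of a 1.1-fold lower number from compound 1 to compound 2 (0.05 log units; within the scatter) shows that this exchange left the read-out essentially unchanged. Among the two numbers so far, compound 2 has the lower one, but the gap to compound 1 lies within the scatter, so the two cannot be ordered.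

Compound 3 `C=CCn1c(=O)/c(=C\c2ccc(C)cc2)[nH]c(=O)/c1=C\c1ccccc1OC` has not yet been measured. It differs from compound 2 as follows: 4-methylphenyl in place of 2-(trifluoromethyl)phenyl on a double-bonded chain carbon bound to an aromatic carbon. Going by the values given here, the only measured step that bears on this change is the earlier aryl swap, a 1.1-fold lower number from compound 1 to compound 2 (0.05 log units; within the scatter), which stayed within the scatter. On that basis no step beyond the scatter is expected in this assay. The expected step is a 1.1-fold higher number from compound 2 to compound 3 (0.04 log units; within the scatter). Compound 3 is therefore estimated at 5000 nM, within a range from 2200 nM to 11000 nM. One exchange is a thin basis, so the range is kept wide.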

Compound 3, half-maximal inhibitory concentration: "not active" (no number reported)
Compound 3: no number reported, so the estimate cannot be set against anything.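

In this assay, going by these compounds alone, compound 3 is reported only as "not active", without a number, so no step from compound 2 to compound 3 can be read. As far as these compounds go, how far 4-methylphenyl in place of 2-(trifluoromethyl)phenyl shifts the read-out therefore stays open. Nothing in the data shown offers an explanation for this result.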